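Swapping the Aryl Group on the Amine of Compound 3

A few compounds are considered here, and "the series" means these few. Any claim that something is new, unique, unknown or untested is made for them only; others in the source may bear on it.

In a functional assay on NCI-H1299 cells (Homo sapiens) for antiproliferative activity, read by MTT assay, with a stated time of 72 h (on this read-out lower numbers stand for stronger inhibition and higher numbers for weaker inhibition), compound 1 `CCOC1=C(C(=O)c2ccccc2)C(c2ccc(Br)cc2)N(CCCn2ccnc2)C1=O` gives 28900 nM, compound 2 `CCOc1ccc(NC2=C(C(=O)c3ccccc3)C(c3ccc(Br)cc3)N(CCCn3ccnc3)C2=O)cc1` gives 20000 nM, and compound 3 `O=C(C1=C(Nc2ccc(OC(F)(F)F)cc2)C(=O)N(CCCn2ccnc2)C1c1ccc(Br)cc1)c1ccccc1` gives 11500 nM. Of the three, the lowest number belongs to compound 3. The gaps were a 2.5-fold lower number from compound 1 to compound 3 (0.40 log units; beyond the scatter) and a 1.7-fold lower number from compound 2 to compound 3 (0.24 log units; within the scatter). Compound 4 `O=C(C1=C(Nc2ccccc2Br)C(=O)N(CCCn2ccnc2)C1c1ccc(Br)cc1)c1ccccc1` differs from compound 3 by 2-bromophenyl in place of 4-(trifluoromethoxy)phenyl on an amine nitrogen. For the measured compounds named here, the one measured step that alters the same aryl group, a 1.7-fold lower number from compound 2 to compound 3 (0.24 log units; within the scatter), was small, and the two steps that introduced the arylamino group, a 1.4-fold lower number from compound 1 to compound 2 (0.16 log units; within the scatter) and a 2.5-fold lower number from compound 1 to compound 3 (0.40 log units; beyond the scatter), were modest at most. Going by the values given here, no measured compound carries a bromine on this ring, so the expectation for compound 4 is a step of a 1.3-fold higher number from compound 3 to compound 4 (0.12 log units; within the scatter) in this assay, not beyond the scatter. Compound 4 is therefore estimated at 15000 nM, with a range from 5000 nM to 45000 nM.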

Compound 4, half-maximal inhibitory concentration: 15600 nM
The estimate for compound 4 lay 1.0-fold (0.02 log units) below the measured number; the range from low to high includes it.
By their numbers in this assay, from the lowest: compounds 3, 4, 2 and 1 (each within the scatter of the next, the first and the last beyond it).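

On this amine nitrogen, 2-bromophenyl reads like both earlier aryl groups in this assay, lying within the scatter of 4-(trifluoromethoxy)phenyl (a 1.4-fold higher number from compound 3 to compound 4 (0.13 log units; within the scatter)) and of 4-ethoxyphenyl (a 1.3-fold lower number from compound 2 to compound 4 (0.11 log units; within the scatter)). Unlike the 4-(trifluoromethoxy)phenyl group, it also stays within the scatter of the ethoxy compound (a 1.9-fold lower number from compound 1 to compound 4 (0.27 log units; within the scatter)), so only compound 3 stands clearly apart from compound 1. No supporting measurement explains these results.

Still open, as far as these compounds go, is whether a carboxylic acid or an amine on this aryl ring would move the number beyond the scatter. The same question applies to a longer alkyl chain replacing the ring.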